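Adding a Second Fluoro to the Lowest Compound

This account rests on a few compounds, and the source may have more. Where it says the series, first, only, none or still open, it means among the compounds named here.

Measured compounds:
compound 1, `CC(=O)c1ccccc1NC(=O)N[C@@H](C)c1ccccc1`, 96%
compound 2, `C[C@H](NC(=O)Nc1ccccc1F)c1ccccc1`, 65%
compound 3, `C[C@H](NC(=O)Nc1ccccc1Br)c1ccccc1`, 102%

In an ADME assay on the whole organism with Oryza sativa as the target, tested at 10 uM (a higher number here means a weaker effect of the compound at the concentration tested, a lower number a stronger effect), compound 2 stands lowest of the three numbers: the step of a number 31 percentage points lower from compound 1 to compound 2 (beyond the scatter) and the step of a number 37 percentage points higher from compound 2 to compound 3 (beyond the scatter) both lie beyond the scatter, whereas the step of a number 6 percentage points higher from compound 1 to compound 3 (within the scatter) stays within it. Compound 4, `C[C@H](NC(=O)Nc1cccc(F)c1F)c1ccccc1`, differs from compound 2 by fluoro in place of hydrogen on an aromatic carbon. Going by the values given here, no measured step adds a group to that ring; the steps that bear on it exchange one group for another there, namely a number 31 percentage points lower from compound 1 to compound 2 (beyond the scatter) and a number 37 percentage points higher from compound 2 to compound 3 (beyond the scatter), both large. They show the number shifts strongly with the group on that ring but give no clear direction for an added fluoro, so a modest upward step is expected, a number 10 percentage points higher from compound 2 to compound 4 (within the scatter). Compound 4 is estimated at 75%, within a range from 50% to 100%.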

Compound 4, a percentage reported as activity, at one concentration (the size of the read-out at that concentration, not a potency): 100%
Compound 4: middle estimate off by 25 percentage points, on the low side; the measured number falls inside the stated range.
By their numbers in this assay, from the lowest: compound 2; then compounds 1, 4 and 3 (each within the scatter of the next).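

In this assay, a fluoro ortho to a fluoro group gives a number 35 percentage points higher from compound 2 to compound 4 (beyond the scatter). The earlier steps shown here only exchanged one group for another, whereas this one keeps the existing fluoro and shows that adding a single fluorine atom at this position can by itself produce a large rise, which means a weaker effect at the concentration tested. No evidence on hand accounts for this rise. The compounds shown leave open whether a chlorine atom, a methyl group or an amine at this position would give a similar rise, and whether a second fluoro on another carbon of that ring would do the same.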